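The source may report more compounds than this note shows. Statements on the series, on what has been measured and on what is new or still open speak of the compounds shown alone.

Of the compounds shown here, three with a shared core have been tested in a functional assay on HCT-116 cells (Homo sapiens) for antiproliferative activity, read by MTT assay, with a stated time of 72 h; on this read-out higher numbers stand for weaker inhibition and lower numbers for stronger inhibition. Compound 1, `COc1ccc(OCCCON2C(N)=NC(N)=NC23CCOCC3)cc1`, gives 1500 nM. Compound 2, `NC1=NC2(CCOCC2)N(OCCCOc2ccc(Cl)cc2)C(N)=N1`, carries a chloro group where compound 1 carries a methoxy group, and compound 2 gives 690 nM. For the measured compounds named here, the single change between them is methoxy in place of chloro on an aromatic carbon, and it makes a step of a 2.2-fold higher number from compound 2 to compound 1 (0.34 log units; beyond the scatter). Compound 3, `NC1=NC2(CCSCC2)N(OCCCOc2ccc(Cl)cc2)C(N)=N1`, differs from compound 2 in the core itself; the difference between the two cores is not broken down here. Compound 3 gives 10 nM, the lowest number of the three.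

Compound 4, `COc1ccc(OCCCON2C(N)=NC(N)=NC23CCSCC3)cc1`, has not yet been measured. It stands to compound 3 as compound 1 stands to compound 2: the change is methoxy in place of chloro on an aromatic carbon. The two place descriptions match word for word. Going by the values given here, this is the same change as the one from compound 2 to compound 1, now made on the core of compound 3. Among the compounds with values here, the only guide to its effect is the modest step of a 2.2-fold higher number from compound 2 to compound 1 (0.34 log units; beyond the scatter), which rests on a single pair, so there is no way to know whether the other core will respond in the same way. If it does, compound 4 is expected to move by a step of a 2.2-fold higher number from compound 3 to compound 4 (0.34 log units; beyond the scatter) in this assay. On that basis, compound 4 is estimated at 22 nM, with a plausible range from 8 nM to 60 nM.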

Compound 4, half-maximal inhibitory concentration: 70 nM
Compound 4: middle estimate off by 3.2-fold (0.50 log units), on the low side; the measured number lies above the stated range.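

In this assay, putting methoxy in place of chloro on the core of compound 3 gives a 7.0-fold higher number from compound 3 to compound 4 (0.85 log units; beyond the scatter), so inhibition weakens on this core as well. For the compounds shown here, the direction of the change therefore carries over from one core to the other, but its size does not: the same change on two cores in this assay, a 2.2-fold higher number (0.34 log units; beyond the scatter) from compound 2 to compound 1 and a 7.0-fold higher number (0.85 log units; beyond the scatter) from compound 3 to compound 4, 3.2-fold (0.51 log units) apart, beyond the scatter of two such steps This shows that, for these two pairs, the step measured on one core would have been a poor guide to the exact size of the step on the other, and that the loss was larger on the core of compound 3; it does not show why the two steps differ, and with only two pairs it sets no rule for any further core.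

The compounds shown leave open how other groups in the place of chloro or methoxy, such as fluoro, a nitrile or an amine, would behave on either core, and whether their steps would also differ from one core to the other. They also leave open whether a longer chain in place of the present linking chain would keep the same gap between the steps on the two cores.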